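The source may hold more compounds than are shown below. What is called first, only, known or untested is meant among the compounds shown, and "the series" means these compounds.

The measured compounds are:
Compound 1, `CS(=O)(=O)c1ccc(C(=O)NCCC(=O)N2CCCCC2)cc1[N+](=O)[O-]`: > 60000 nM, which is a limit of the assay and not a number.
Compound 2, `CS(=O)(=O)c1ccc(C(=O)NCC(=O)N(Cc2ccccc2)Cc2ccccc2)cc1[N+](=O)[O-]`: 3600 nM.
Compound 3, `CS(=O)(=O)c1ccc(C(=O)NCC(=O)N2CCN(c3ccccc3F)CC2)cc1[N+](=O)[O-]`: > 60000 nM, again a limit of the assay rather than a number.

All three were tested in an assay on isolated protein for inhibition of thyroid hormone receptor beta (Homo sapiens), read by fluorescence polarization; on this read-out lower numbers stand for stronger inhibition and higher numbers for weaker inhibition. Compound 1 stands at the limit of > 60000 nM in this assay, at which 2 of the 3 values shown sit, so nothing more is known of it than that its inhibition was too weak for the assay to resolve. Compound 2 is the only one of the three for which this assay returned a number. Within the data shown here, no pair among the measured compounds differs in a single place, so no measured step is available to calibrate the change that follows.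

Compound 4, `CC(C)N(C(=O)CCNC(=O)c1ccc(S(C)(=O)=O)c([N+](=O)[O-])c1)C(C)C`, has not been measured. It differs from compound 1 in one place: diisopropylamino in place of piperidin-1-yl on a carbonyl carbon. In this assay the expected step is a step that the limit leaves unreadable from compound 1 to compound 4, that is, none beyond the scatter, since the starting point is a limit and the change swaps one small amide substituent for another of similar size. Compound 4 is accordingly estimated at 90000 nM in this assay, within a range from 20000 nM to 400000 nM, and it is expected that the assay will again most likely report only a limit.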

Compound 4, half-maximal inhibitory concentration: > 60000 nM
Compound 4 gave a limit, no number (the forecaster's own chance of this, stated with the estimate: 75%); the middle value does not contradict the limit.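

Among these compounds, compound 1 and compound 4 both give only a limit of the assay and not a number, so no step between them can be read: the limit of > 60000 nM in this assay, at which 3 of the 4 values shown sit. The compounds shown leave open whether diisopropylamino in place of piperidin-1-yl on a carbonyl carbon changes inhibition at all, and how far either compound lies beyond that limit.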